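A few compounds are considered here, and "the series" means these few. Any claim that something is new, unique, unknown or untested is made for them only; others in the source may bear on it.

Measured so far in a functional assay (a higher number here means a weaker inhibitor, a lower number a stronger inhibitor), are three compounds:
- compound 1 `CC(C)=CCOc1ccc2c(c1)OC(c1ccccc1)CC2=O` with 6070 nM as its value
- compound 2 `CC(C)=CCOc1ccc2c(c1)OC(c1ccccc1F)CC2=O` with 6360 nM as its value
- compound 3 `CC(C)=CCOc1cc(O)c2c(c1)OC(c1ccccc1F)CC2=O` with 5300 nM as its value

Compound 3 stands level with the other two, as all three values lie within the usual scatter of one another. Fluoro in place of hydrogen on an aromatic carbon gives a 1.0-fold higher number from compound 1 to compound 2 (0.02 log units; within the scatter) and hydroxy in place of hydrogen on an aromatic carbon gives a 1.2-fold lower number from compound 2 to compound 3 (0.08 log units; within the scatter) as its step, so neither change moved the number measurably.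

Compound 4 `CC(C)=CCOc1cc(O)c2c(c1)OC(c1cccc(Br)c1)CC2=O` is still unmeasured. It has 3-bromophenyl in place of 2-fluorophenyl on a saturated ring carbon and is otherwise the same as compound 3. Within the data shown here, only the fluoro step touches this phenyl group, and no compound measured so far carries bromine, so the evidence is thin. No step beyond the scatter is therefore expected in this assay for this change, in either direction. The expected change is a 1.1-fold lower number from compound 3 to compound 4 (0.03 log units; within the scatter) on this estimate. For compound 4 the estimated value is 5000 nM with an expected range from 2000 nM to 12000 nM as its limits of confidence.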

Compound 4, half-maximal inhibitory concentration: 4040 nM
Compound 4: middle estimate off by 1.2-fold (0.09 log units), on the high side; low and high end bracket the measured number.
By their numbers in this assay, from the lowest: compounds 4, 3, 1 and 2 (each within the scatter of the next).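

In this assay the swap of 2-fluorophenyl for 3-bromophenyl on the saturated ring carbon gives a 1.3-fold lower number from compound 3 to compound 4 (0.12 log units; within the scatter) and so does not move the number measurably. The earlier fluoro step showed only that adding one fluorine to the phenyl group changes nothing measurable, whereas this step changes both the halogen and where it sits on that phenyl group, and the number still holds level. No measurement shown here offers an explanation for this result.

Compound 4 changes the halogen and its place at once, so a 3-fluorophenyl or 2-bromophenyl group would be needed to tell those two changes apart. On these data alone, it also remains open whether a different kind of group on this phenyl, such as an amine or a carboxylic acid, would give a step beyond the scatter.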